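Thioester in place of ester on the shared core

This account rests on a few compounds, and the source may have more. Where it says the series, first, only, none or still open, it means among the compounds named here.

Compound 1 `CC1=C(C(=O)OCC(C)C)C(c2cccs2)NC(=O)N1` stands second highest of the three numbers in an assay on membranes from CHO cells for displacement of a labelled ligand from adenosine receptor A1 (Homo sapiens), read by scintillation counting, with a stated time of 60 min, tested at 1 uM (on this read-out higher numbers stand for more inhibition at the one concentration tested (going by the name of the read-out) and lower numbers for less inhibition), where compound 1 gives 25%. Compound 3 `CC1=C(C(=O)OCC(C)C)C(c2cccs2)NC(=O)N1C`, the nearest, gives 9% in this assay; compound 2 `CC1=C(C(=O)OCc2ccccc2)C(c2ccsc2)NC(=O)N1`, the furthest, gives 57%. Within the data shown here, the one single-point step measured is a number 16 percentage points lower from compound 1 to compound 3 (beyond the scatter). Compound 2 differs from compound 1 in two places at once, so its number is all it shows.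

Compound 4 `CCSC(=O)C1=C(C)NC(=O)NC1c1cccs1` is not yet measured. It differs from compound 1 as follows: ethylsulfanyl in place of isobutoxy on a carbonyl carbon. The isobutoxy leaves and ethylsulfanyl enters on the carbonyl carbon whose other neighbour is a double-bonded ring carbon. Among the measured compounds shown here, no measured step touches this carbonyl carbon; the only measured step, methyl in place of hydrogen on an amide-type nitrogen in a ring, bears on a different part of the core and gives no guide here. With nothing in the data pointing either way, the expected step in this assay is no change at the digits printed from compound 1 to compound 4 (within the scatter), none beyond the scatter. For compound 4 the expected value in this assay is 25%, within 8% to 45%.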

Compound 4, a percentage reported as inhibition, at one concentration (the size of the read-out at that concentration, not a potency): 6%
Compound 4: the middle estimate sits 19 percentage points above what was measured, outside the stated range (below it).
By their numbers in this assay, from the lowest: compounds 4 and 3 (each within the scatter of the next); then compound 1; then compound 2.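

The carbonyl carbon on the shared core responds to change: in this assay, ethylsulfanyl in place of isobutoxy gives a number 19 percentage points lower from compound 1 to compound 4 (beyond the scatter), the first step measured at this place. The change alters the linking atom and the chain together, with isobutoxy at 5 heavy atoms and ethylsulfanyl at 3, so this single step cannot assign the loss to either. Nothing in the data shown bears on the cause of this step.

Still open, on these data alone, is whether the linking atom or the chain carries the step: an ethoxy group or an isobutylsulfanyl group on this carbonyl carbon would separate the two. Also open, as far as these compounds go, is how an amide nitrogen bearing a short chain would fare at this place, and compound 2 cannot guide this, as it differs from compound 1 in two places.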